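Moving the Halogen on the Benzamide of Compound 3

The compounds below may be only part of what the source reports. "The series", "measured", "known", "first", "only" and "open" are said of these compounds alone.

compound 1 `COc1cc2ncnc(Nc3ccc(NC(=O)c4ccc(C)cc4)cc3)c2cc1OC` gives 25000 nM
compound 2 `CCc1ccc(C(=O)Nc2ccc(Nc3ncnc4cc(OC)c(OC)cc34)cc2)cc1` gives 72000 nM
compound 3 `COc1cc2ncnc(Nc3ccc(NC(=O)c4ccc(F)cc4)cc3)c2cc1OC` gives 15000 nM

In a functional assay on HepG2 cells (Homo sapiens) for inhibition, read by MTT assay (a higher number here means a weaker inhibitor, a lower number a stronger inhibitor), compound 3 shares the low end of the range with compound 1 and the measured change a 1.7-fold lower number from compound 1 to compound 3 (0.22 log units; within the scatter) does not separate them. Compound 2 stands apart, with a 4.8-fold lower number from compound 2 to compound 3 (0.68 log units; beyond the scatter) as the measured change.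

The next compound, compound 4 `COc1cc2ncnc(Nc3ccc(NC(=O)c4cccc(Cl)c4)cc3)c2cc1OC` has 3-chlorophenyl in place of 4-fluorophenyl on a carbonyl carbon and nothing else differs. Going by the values given here, no measured compound contains chlorine, so no step measures this change directly. The steps at this same group give only a scale. Fluoro in place of methyl gave a 1.7-fold lower number from compound 1 to compound 3 (0.22 log units; within the scatter) and methyl added to the saturated chain carbon gave a 2.9-fold higher number from compound 1 to compound 2 (0.46 log units; beyond the scatter) with both of these staying small or modest.

With compound 3 at 15000 nM lying at the low end of these values, a drift towards higher numbers seems slightly more likely than one towards lower numbers. Among the compounds with values here, the expected change is a 1.7-fold higher number from compound 3 to compound 4 (0.22 log units; within the scatter) and no larger step is anticipated. Compound 4 is expected at about 25000 nM in this assay as the central estimate. The estimated range for compound 4 runs from 10000 nM to 60000 nM on this reading.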

Compound 4, half-maximal inhibitory concentration: 12000 nM
Compound 4: middle estimate off by 2.1-fold (0.32 log units), on the high side; low and high end bracket the measured number.
By their numbers in this assay, from the lowest: compounds 4, 3 and 1 (each within the scatter of the next, the first and the last beyond it); then compound 2.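

In this assay, 3-chlorophenyl on a carbonyl carbon reads much like 4-fluorophenyl, with a 1.3-fold lower number from compound 3 to compound 4 (0.10 log units; within the scatter) as the measured change, so this exchange, which alters the halogen and its place on the phenyl ring at once, leaves the number where compound 3 had it. Compound 4 nevertheless adds a comparison that compound 3 could not give: a 2.1-fold lower number from compound 1 to compound 4 (0.32 log units; beyond the scatter) is a modest step that stands clear of the scatter, and a 6.0-fold lower number from compound 2 to compound 4 (0.78 log units; beyond the scatter) is the widest step yet seen at this position, so both halogen-bearing phenyl groups stay on the side of the range away from 4-ethylphenyl, while 4-methylphenyl is separated from only one of them. Nothing available here accounts for these differences at this position.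

Because the halogen and its place changed together in this one step, the compounds shown cannot assign the small measured change to either alone. They also leave open how a phenyl carrying a nitrile, an amine or a carboxylic acid would read on the same carbonyl carbon, and whether any such group would bring the numbers outside the narrow span now held by compound 1, compound 3 and compound 4.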